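Iminosugar triazoles and coffee alpha-galactosidase: an epimer step

The compounds below may be only part of what the source reports. "The series", "measured", "known", "first", "only" and "open" are said of these compounds alone.

Measured so far:
compound 1, `O[C@@H]1[C@H](O)CN[C@@H]1Cn1cc(-c2ccccc2)nn1`: <= 50%
compound 2, `O=C(NC[C@@H]1NC[C@@H](O)[C@H]1O)c1ccccc1`: "not active" (no number reported)

In an assay on isolated protein for inhibition of alpha-galactosidase (Coffea arabica), with stated times of 5 min and 20 min, tested at 1 mM (on this read-out lower numbers stand for less inhibition and higher numbers for more inhibition at the one concentration tested (going by the name of the read-out)), compound 1 gives <= 50%, which is a limit of the assay and not a number (the limit of <= 50% in this assay, at which 1 of the 2 values shown sits). In this assay compound 2 gives "not active" (no number reported), with no figure attached. Among the compounds with values here, no step between measured compounds can be drawn from these two entries.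

Compound 3, `O[C@@H]1[C@H](O)CN[C@H]1Cn1cc(-c2ccccc2)nn1`, differs from compound 1 as follows: the two compounds have the same atoms and bonds and differ only in configuration as drawn: 1 of 3 stereo elements differ; a stereocentre at a saturated ring carbon is drawn R in compound 1 and S in compound 3.

With compound 1 already at a limit, no step beyond the scatter is expected: a step that the limit leaves unreadable from compound 1 to compound 3. Compound 3 is estimated to give 25%, within 5% to 50%, and may well return only a limit again.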

Compound 3, a percentage reported as inhibition, at one concentration (the size of the read-out at that concentration, not a potency): < 50%
Compound 3 gave a limit, no number; the forecaster's own chance of this, stated with the estimate: 60%; the middle value lies beyond the limit too.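

Compound 1 gives <= 50%, a limit and not a number. Within the data shown here, compound 3 gives < 50%, also a limit, so no step to compound 1 can be read. Open remains whether inverting this one ring stereocentre changes inhibition at all.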